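The source may report more compounds than this note shows. Statements on the series, on what has been measured and on what is new or still open speak of the compounds shown alone.

Measured compounds:
compound 1 `COc1cc(/C=C/C(=O)/C=C/c2cccs2)ccc1OCc1cn(CCCCCOc2cc(=O)oc3ccccc23)nn1`, in a functional assay on HCT-116 cells (Homo sapiens) for inhibition, read by sulforhodamine B assay, with a stated time of 48 h, tested at 50 uM (on this read-out lower numbers stand for less inhibition of growth and higher numbers for more inhibition of growth at the one concentration tested), compound 1 gives 31%;
compound 2 `COc1cc(/C=C/C(=O)/C=C/c2cccc3ccccc23)ccc1OCc1cn(CCCCOc2cc(=O)oc3ccccc23)nn1`, in this assay compound 2 gives 56%;
compound 3 `COc1cc(/C=C/C(=O)/C=C/c2cccc3ccccc23)ccc1OCc1cn(CCOc2cc(=O)oc3ccccc23)nn1`, in this assay compound 3 gives 83%.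

Compound 2 stands second highest of the three numbers. Its nearest neighbour is compound 1, whose value lies lower by a margin beyond the scatter; compound 3 lies furthest away, higher by a margin that is also beyond the scatter. For the measured compounds named here, no two of the measured compounds differ in one place only, so no single step between them is recorded.

The unmeasured compound 4 `COc1cc(/C=C/C(=O)/C=C/c2cccs2)ccc1OCc1cn(CCCCOc2cc(=O)oc3ccccc23)nn1` departs from compound 2 in one place: thiophen-2-yl in place of naphthalen-1-yl on a double-bonded chain carbon bound to a double-bonded chain carbon. Compound 1 also carries the thiophen-2-yl group, though it differs from compound 4 elsewhere as well, and compound 1 holds the lowest of the three numbers. On that ground a downward step in this assay is expected from compound 2 to compound 4, of a size likely beyond the scatter, a number 16 percentage points lower from compound 2 to compound 4 (beyond the scatter). Compound 4 is estimated at 40%, within a range from 22% to 58%.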

Compound 4, percent growth inhibition at one concentration: 41%
Estimate against measurement, compound 4: 1 percentage points below; the range from low to high includes it.
By their numbers in this assay, from the lowest: compounds 1 and 4 (each within the scatter of the next); then compound 2; then compound 3.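

In this assay, for the compounds shown here, the exchange of naphthalen-1-yl for thiophen-2-yl on a double-bonded chain carbon bound to a double-bonded chain carbon gives a number 15 percentage points lower from compound 2 to compound 4 (beyond the scatter), and this is the first reading of a change in one place only. It shows that the number responds to the group at this position, with the group of 5 heavy atoms and one five-membered aromatic ring going with less inhibition of growth in this pair than the group of 10 heavy atoms and two six-membered aromatic rings. Nothing measured here bears on what lies behind this step.

The compounds shown leave open where a plain phenyl group or a 4-aminophenyl group at this place would fall relative to these two groups. They also leave open whether the same exchange would give a step of similar size on a hexyl chain.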